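The source may report more compounds than this note shows. Statements on the series, on what has been measured and on what is new or still open speak of the compounds shown alone.

Compounds measured:
Compound 1 `CC(C)[C@H](NC(=O)COc1cccc2ccccc12)C(=O)N[C@@H](CC(=O)O)C(=O)COc1ccc(C#N)cc1` — > 100000 nM
Compound 2 `CC(C)[C@H](NC(=O)COc1cccc2ccccc12)C(=O)N[C@@H](CC(=O)O)C(=O)COc1ccc(C(N)=O)cc1` — > 100000 nM
Compound 3 `CC(C)[C@H](NC(=O)COc1cccc2ccccc12)C(=O)N[C@@H](CC(=O)O)C(=O)COc1c(F)cccc1F` — 2040 nM

Compound 1 `CC(C)[C@H](NC(=O)COc1cccc2ccccc12)C(=O)N[C@@H](CC(=O)O)C(=O)COc1ccc(C#N)cc1` gives only a limit in a functional assay on Jurkat cells (Homo sapiens) (a higher number here means a weaker inhibitor, a lower number a stronger inhibitor), namely > 100000 nM. Compound 2 `CC(C)[C@H](NC(=O)COc1cccc2ccccc12)C(=O)N[C@@H](CC(=O)O)C(=O)COc1ccc(C(N)=O)cc1` likewise gives only a limit, > 100000 nM. Compound 3 `CC(C)[C@H](NC(=O)COc1cccc2ccccc12)C(=O)N[C@@H](CC(=O)O)C(=O)COc1c(F)cccc1F` gives a number, 2040 nM, so compound 1 stands at the weak end of what is shown, where two of the three values sit (the limit of > 100000 nM in this assay, at which 2 of the 3 values shown sit).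

Compound 4 `CC(C)[C@H](NC(=O)COc1cccc2ccccc12)C(=O)N[C@@H](CC(=O)O)C(=O)COc1c(F)c(F)c(F)c(F)c1F` has not been measured. It differs from compound 1 by 2,3,4,5,6-pentafluorophenyl in place of 4-cyanophenyl on an oxygen on a saturated carbon. The measured step that bears on this is the one with 2,6-difluorophenyl in place of 4-cyanophenyl, an at least 49-fold lower number from compound 1 to compound 3 (1.69 log units; beyond the scatter), and its counterpart from compound 2, an at least 49-fold lower number from compound 2 to compound 3 (1.69 log units; beyond the scatter); both are large and in the direction of a stronger inhibitor, though their size is only a lower bound. Since the entering group of compound 4 is again a fluorinated phenyl, a step of similar direction and size is expected, an at least 66-fold lower number from compound 1 to compound 4 (1.82 log units; beyond the scatter). Compound 4 is therefore estimated at 1500 nM, within 300 nM to 10000 nM.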

Compound 4, half-maximal inhibitory concentration: 3050 nM
Beside the measured number, compound 4's estimate is 2.0-fold (0.31 log units) below it, within the range that was stated.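

At this position, on an oxygen on a saturated carbon, 2,3,4,5,6-pentafluorophenyl also gives a readable value in this assay, with an at least 32-fold lower number from compound 1 to compound 4 (1.51 log units; beyond the scatter) and an at least 32-fold lower number from compound 2 to compound 4 (1.51 log units; beyond the scatter), so the earlier result is not confined to 2,6-difluorophenyl. The two fluorinated groups cannot be told apart here: a 1.5-fold higher number from compound 3 to compound 4 (0.17 log units; within the scatter). The two larger steps are only lower bounds, because the values they start from are limits and not numbers: the limit of > 100000 nM in this assay, at which 2 of the 4 values shown sit.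

The compounds shown leave open whether fluorine is needed at all, a question that an unsubstituted phenyl or a chlorophenyl on this oxygen would address. Also open, as far as these compounds go, is how a group without an aromatic ring, such as cyclohexyl, would read at this position.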